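The source may hold more compounds than are shown below. What is called first, only, known or untested is meant among the compounds shown, and "the series" means these compounds.

Of the compounds shown here, two of the shared core have been measured in an assay on cell membranes for displacement of a labelled ligand from corticotropin-releasing factor receptor 1 (Rattus norvegicus); a lower number here means a stronger inhibitor, a higher number a weaker inhibitor. Compound 1 `CCC(CC)Nc1nc(C)nc2c(-c3c(C)cc(N(C)C)nc3C)c(C)nn12` carries a (pentan-3-yl)amino group and gives 25.6 nM. Compound 2 `CCCN(CCC)c1nc(C)nc2c(-c3c(C)cc(N(C)C)nc3C)c(C)nn12` carries a dipropylamino group in that position and gives 14.9 nM; on these two numbers compound 2 has the lower one, but the step of a 1.7-fold lower number from compound 1 to compound 2 (0.24 log units; within the scatter) is within the scatter, so the two cannot be told apart with confidence.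

Compound 3 `CCN(CC)c1nc(C)nc2c(-c3c(C)cc(N(C)C)nc3C)c(C)nn12` is the next member: it has diethylamino in place of dipropylamino on an aromatic carbon. Among the compounds with values here, the only measured step, a 1.7-fold lower number from compound 1 to compound 2 (0.24 log units; within the scatter), changes the same amino group and did not move the number beyond the scatter, so it gives a weak guide. A step for compound 3 from compound 2 of a 2.0-fold higher number from compound 2 to compound 3 (0.30 log units; within the scatter) is expected, with no firm direction beyond the scatter. The value of compound 3 in this assay is therefore estimated at 30 nM, within a range from 10 nM to 90 nM.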

Compound 3, half-maximal inhibitory concentration: 58 nM
Compound 3: the middle estimate sits 1.9-fold (0.29 log units) below what was measured, within the range that was stated.
By their numbers in this assay, from the lowest: compounds 2 and 1 (each within the scatter of the next); then compound 3.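

In this assay, within the data shown here, diethylamino in place of dipropylamino, a group of 5 heavy atoms replacing one of 7, gives a 3.9-fold higher number from compound 2 to compound 3 (0.59 log units; beyond the scatter) and is the first step at this position to lie beyond the scatter. This amino group can therefore move the number even though the hydrogen-bond donor and acceptor counts of the two groups are the same. Diethylamino in place of (pentan-3-yl)amino gives a 2.3-fold higher number from compound 1 to compound 3 (0.36 log units; beyond the scatter) and is also beyond the scatter, so compound 3 stands apart from compounds 1 and 2, and nothing available explains why this change has this effect.

From the compounds shown here alone, whether a longer chain such as dibutylamino would lower the number further remains open. The effect of a ring amine such as morpholine or piperidine at this position is also unknown.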